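From 2-bromophenyl to 3-methylphenyl on a sulfonyl sulfur

The source may hold more compounds than are shown below. What is called first, only, known or untested is meant among the compounds shown, and "the series" means these compounds.

In a functional assay on HEK293 cells (Homo sapiens) for cytotoxicity (a higher number here means that more compound is tolerated, a lower number that less compound is tolerated), compound 3 (`COc1ccc([C@H]2CC(=O)N(c3cccc(NS(=O)(=O)c4ccccc4Br)c3)C2)cc1OC1CCCC1`) gives > 10000 nM as a limit and not a number. Compound 1 (`COc1ccc([C@H]2CC(=O)N(c3cccc(NCCCc4ccccc4)c3)C2)cc1OC1CCCC1`) also gives a limit of > 10000 nM in this small set. Compound 2 (`COc1ccc([C@H]2CC(=O)N(c3cccc(NS(=O)(=O)c4cccc(OC(F)(F)F)c4)c3)C2)cc1OC1CCCC1`) likewise gives a limit of > 10000 nM here. So the limit of > 10000 nM in this assay, at which 3 of the 3 values shown sit, describes the whole set so far, and compound 3 cannot be ranked against the other two.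

Compound 4 (`COc1ccc([C@H]2CC(=O)N(c3cccc(NS(=O)(=O)c4cccc(C)c4)c3)C2)cc1OC1CCCC1`) has 3-methylphenyl in place of 2-bromophenyl on a sulfonyl sulfur. Going by the values given here, two measured steps bear on this change. The closer is a step that the two limits leave unreadable from compound 2 to compound 3 at the same sulfonyl sulfur, and the other is a step that the two limits leave unreadable from compound 1 to compound 3 on the nitrogen. Neither has a readable size, but both end at compound 3 and start from a compound with a limit. No step beyond the usual scatter is therefore expected in this assay, and the estimated step that the limit leaves unreadable from compound 3 to compound 4 has no firm direction. Compound 4 will most likely give a limit too. If a number appears, the estimate for compound 4 is 12000 nM with an expected range from 6000 nM to 30000 nM at the upper end.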

Compound 4, half-maximal cytotoxic concentration: > 10000 nM
Compound 4: no number, only a limit; the forecaster's own chance of this, stated with the estimate: 90%; the middle value lies beyond the limit too.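

In this assay compound 4 gives only a limit, so its steps from compound 1, compound 2 and compound 3 cannot be read: the limit of > 10000 nM in this assay, at which 4 of the 4 values shown sit. As far as these compounds go, how far these four compounds truly differ in the concentration tolerated, and whether their differing groups matter, stays open.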